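A Second Fluorine on the Phenyl Group of Compound 2

A few compounds are considered here, and "the series" means these few. Any claim that something is new, unique, unknown or untested is made for them only; others in the source may bear on it.

Of the compounds shown here, two sharing one core have been measured in a functional assay on CHO cells with adenosine receptor A1 (Homo sapiens) as the target, read by cAMP accumulation and immunoassay, with a stated time of 6 min, tested at 0.01 uM; on this read-out lower numbers stand for a stronger effect and higher numbers for a weaker effect at the one concentration tested. Compound 1 `Nc1scc(CN2CCN(c3ccc([N+](=O)[O-])cc3)CC2)c1C(=O)c1ccc(Cl)cc1` carries a 4-nitrophenyl on an amine nitrogen in a ring, and in this assay compound 1 gives -12%. Compound 2 `Nc1scc(CN2CCN(c3cccc(F)c3)CC2)c1C(=O)c1ccc(Cl)cc1` carries a 3-fluorophenyl at that place, and in this assay compound 2 gives -18%. For the measured compounds named here, the single step so far, a number 6 percentage points lower from compound 1 to compound 2 (within the scatter), amounts to no real difference; compound 2 stands at the lower of the two numbers, but the gap is within the scatter, and both readings sit close to zero, so neither compound does much at this concentration.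

Compound 3 `Nc1scc(CN2CCN(c3cccc(F)c3F)CC2)c1C(=O)c1ccc(Cl)cc1` differs from compound 2 by fluoro in place of hydrogen on an aromatic carbon, turning the 3-fluorophenyl into a 2,3-difluorophenyl. Going by the values given here, no measured step concerns adding a second fluoro to this ring; the only known step exchanged the whole group and still stayed within the scatter. Among the compounds with values here, with two near-zero readings and no step that moved beyond the scatter, the expectation for a number 3 percentage points higher from compound 2 to compound 3 (within the scatter) is no change beyond the scatter. Compound 3 is therefore expected to give -15%, within a range from -30% to 0%.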

Compound 3, a percentage reported as activity, at one concentration (the size of the read-out at that concentration, not a potency): -13%
Compound 3: middle estimate off by 2 percentage points, on the low side, within the range that was stated.
By their numbers in this assay, from the lowest: compounds 2, 3 and 1 (each within the scatter of the next).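

In this assay, for the compounds shown here, putting fluoro on an aromatic carbon, ortho to a fluoro group and ortho to a large group, gives a number 5 percentage points higher from compound 2 to compound 3 (within the scatter) and so does not separate the two compounds; this is the first step that keeps the 3-fluorophenyl and alters just one spot on that ring, and here that small edit leaves the reading where a wholesale exchange of the group had left it. The wholesale exchange also reads the same with the new group, as 2,3-difluorophenyl in place of 4-nitrophenyl gives a number 1 percentage points lower from compound 1 to compound 3 (within the scatter) and all three compounds lie within the scatter of one another. No other measurement bears on this result, so nothing can be said about what lies behind it.

Still open, as far as these compounds go, is whether a different group at this place on the ring, such as a methoxy, an amine or a carboxylic acid, would move the reading beyond the scatter. From the compounds shown here alone, a reading at one concentration is also not a potency, so how these compounds compare across a range of concentrations remains unknown.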